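This account rests on a few compounds, and the source may have more. Where it says the series, first, only, none or still open, it means among the compounds named here.

Working notes on the series in an assay on HEK-293T cells for displacement of a labelled ligand from corticotropin-releasing factor receptor 1 (Homo sapiens), read by scintillation counting, with a stated time of 2 h; a higher number here means a weaker inhibitor, a lower number a stronger inhibitor.

Compound 1, `CCCCN(CC)c1cc(C)nc2c1NC(=O)CN2c1ccc(C)cc1C`, gives 3.9 nM in this assay. For the measured compounds named here, that is the highest of the two numbers available, and the only neighbour is compound 2, `CCCCN(CC)c1cc(C)nc2c1NC(=O)CN2c1ccc(Cl)cc1Br`, which gives 2.5 nM in this assay. The step between them, a 1.6-fold lower number from compound 1 to compound 2 (0.19 log units; within the scatter), exchanges both substituents of the aryl group at once: 2-bromo-4-chlorophenyl in place of 2,4-dimethylphenyl on a nitrogen on an aromatic ring in a ring. Both compounds therefore stand within the scatter of each other, and no order between them can be read.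

Compound 3, `CCCCN(CC)c1cc(C)nc2c1NC(=O)CN2c1ccc(C)cc1Br`, is not yet measured. Relative to compound 1 its change is bromo in place of methyl on an aromatic carbon, read one bond further out as 2,4-dimethylphenyl to 2-bromo-4-methylphenyl. This is part of the change already carried in the step from compound 1 to compound 2, which stayed within the scatter. Going by the values given here, no step isolating bromo for methyl alone exists here, so the only bearing evidence is that combined step, and from it no movement beyond the scatter is expected, a 1.2-fold lower number from compound 1 to compound 3 (0.09 log units; within the scatter). The value of compound 3 in this assay is estimated at 3.2 nM, with a range of 1.5 nM to 7 nM.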

Compound 3, inhibition constant: 4.4 nM
The estimate for compound 3 lay 1.4-fold (0.14 log units) below the measured number, and the stated range covers the measured number.
By their numbers in this assay, from the lowest: compounds 2, 1 and 3 (each within the scatter of the next).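

Bromo in place of methyl on an aromatic carbon, ortho to a large group, can now be read as a single change in this assay (a 1.1-fold higher number from compound 1 to compound 3 (0.05 log units; within the scatter)), and methyl in place of chloro on an aromatic carbon can be read separately (a 1.8-fold higher number from compound 2 to compound 3 (0.25 log units; within the scatter)). The double exchange in the aryl group thus splits into two single exchanges, and neither moves the number beyond the scatter, so methyl and bromo at the first position, and chloro and methyl at the second, cannot be told apart on these data, and compounds 1, 2 and 3 take no firm order. Nothing available beyond these binding numbers bears on this result.

The compounds shown carry only methyl, bromo and chloro on the aryl group, so it remains open whether a methoxy group, an amine or a carboxylic acid on either aromatic carbon would also stay within the scatter. Going by these compounds, the butyl and ethyl chains on the amine nitrogen and the amide hydrogen are the same throughout, so the response of the number to a longer chain or to a methyl group on the amide nitrogen also remains open.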